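The compounds below may be only part of what the source reports. "The series", "measured", "known", "first", "only" and "open" are said of these compounds alone.

Measured compounds:
- compound 1 `COc1nc(-c2cc3ccccc3o2)cc(-c2ccc(Br)cc2)c1C#N`: 298000 nM
- compound 2 `COc1nc(-c2cc3ccccc3o2)cc(-c2ccc(C)cc2)c1C#N`: 266000 nM
- compound 3 `CCOc1nc(-c2cc3ccccc3o2)cc(-c2ccc(C)cc2)c1C#N`: 290000 nM

All three share one core and differ only in the ring on the aromatic carbon of the core or in the alkoxy group. In a functional assay on aorta (strain Wistar) for inhibition, with Thoracic aorta (Rattus norvegicus) as the target (a higher number here means a weaker inhibitor, a lower number a stronger inhibitor), compound 2 gives 266000 nM, and its steps to both neighbours are within the scatter: a 1.1-fold lower number from compound 1 to compound 2 (0.05 log units; within the scatter) and a 1.1-fold higher number from compound 2 to compound 3 (0.04 log units; within the scatter). Among the compounds with values here, compound 2 therefore stands together with compound 1 and compound 3, with no step among the three resolved.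

Compound 4 `COc1nc(-c2cc3ccccc3o2)cc(-c2ccc(C)o2)c1C#N` is not yet measured. The change from compound 2 is 5-methylfuran-2-yl in place of 4-methylphenyl on an aromatic carbon. Within the data shown here, of the measured steps, only the step from compound 1 to compound 2 touches the same ring, and it was within the scatter; the step from compound 2 to compound 3 changes the alkoxy group and was also within the scatter. Neither step tests a replacement of the whole ring, so the evidence is thin. With nothing pointing either way, the expected step is a 1.0-fold higher number from compound 2 to compound 4 (0.01 log units; within the scatter), that is none beyond the scatter, and compound 4 is estimated at 270000 nM in this assay, with a range from 110000 nM to 650000 nM.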

Compound 4, half-maximal inhibitory concentration: 285000 nM
For compound 4 the middle estimate is 1.1-fold (0.02 log units) below the measured one, and the stated range covers the measured number.
By their numbers in this assay, from the lowest: compounds 2, 4, 3 and 1 (each within the scatter of the next).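

In this assay, exchanging the whole ring on the aromatic carbon opposite the ring nitrogen gives a 1.1-fold higher number from compound 2 to compound 4 (0.03 log units; within the scatter) and a 1.0-fold lower number from compound 1 to compound 4 (0.02 log units; within the scatter). The earlier steps shown here altered only the substituent on that ring or the alkoxy group, whereas here a six-membered aromatic ring of carbon only gives way to a five-membered aromatic ring with 1 hetero atom, and no change is resolved for either pair. Nothing available bears on why these compounds cannot be told apart.

As far as these compounds go, all four compounds stand together, so it remains open whether any group at this position can move the number beyond the scatter. An aromatic ring carrying an amine or a carboxylic acid, or a longer chain in place of the methoxy group, would be an untested change to the shared core.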